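A few compounds are considered here, and "the series" means these few. Any claim that something is new, unique, unknown or untested is made for them only; others in the source may bear on it.

Compound 2 `FC(F)Oc1ccccc1C1Cc2nccn2C1` carries a difluoromethoxy group on its phenyl ring, and in a physicochemical assay for lipophilicity, at pH 7.4 (on this read-out lower numbers stand for lower lipophilicity and higher numbers for higher lipophilicity), compound 2 gives 2.3. Among the single numbers shown this is the lowest; the nearest is compound 3 `COc1ccc(C2CCc3nc[nH]c3C2)cc1`, which in this assay gives 2.6, a gap that lies within the scatter. Compound 1 `c1ccc(C2Cc3nccn3C2)cc1` has two entries in this assay, 1.9; 2.2 (2 entries), and their spread is itself a picture of the repeat scatter (the several entries of compound 1 in this assay, 1.9; 2.2 (2 entries)). Compound 4 `Clc1ccccc1C1Cc2nccn2C1` has not yet been measured; it differs from compound 2 by chloro in place of difluoromethoxy on an aromatic carbon. Within the data shown here, no measured pair shows this change. A small upward step, hardly beyond the scatter, is expected a number 0.30 log units higher from compound 2 to compound 4 (within the scatter). Compound 4 is therefore estimated at 2.6, between 2.2 and 3.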

Compound 4, distribution coefficient: 2.6
Compound 4: middle estimate and measured number agree at the digits printed, and the stated range covers the measured number.
By their numbers in this assay, from the lowest: compounds 2, 3 and 4 (each within the scatter of the next).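

In this assay, the exchange of chloro for difluoromethoxy on an aromatic carbon gives the only single-place comparison among these compounds: a number 0.30 log units higher from compound 2 to compound 4 (within the scatter). Thus this position tolerates the loss of difluoromethoxy, with its 4 heavy atoms, for chloro, with 1 heavy atom, without a step that can be told from repeat variation. A gap of this size also appears between repeat entries of one compound: the several entries of compound 1 in this assay, 1.9; 2.2 (2 entries)

The compounds shown leave open how an amine or a carboxylic acid at this position would read in this assay. They also leave open whether the same exchange gives a similar step on a different core.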